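This account rests on a few compounds, and the source may have more. Where it says the series, first, only, none or still open, it means among the compounds named here.

Of the compounds shown here, three of a shared core have so far been tested in an ADME assay on BHK cells (Mesocricetus auratus) for cytotoxicity, read by MTT assay, with a stated time of 96 h; on this read-out higher numbers stand for lower toxicity in this test and lower numbers for higher toxicity in this test. Compound 1 `O=[N+]([O-])c1ccc(-c2nc3cc(C(F)(F)F)ccc3[nH]2)c([N+](=O)[O-])c1` gives 8000 nM in this assay. Compound 2 `O=C(CN1CCCC1)Nc1ccc(-c2nc3ccccc3[nH]2)cc1` gives 55000 nM in this assay, the higher of the two numbers, and its gap to compound 1 lies beyond the usual scatter of such measurements. For compound 3 `COc1cc(OC)cc(-c2nc3cc(C(F)(F)F)ccc3[nH]2)c1` this assay reports only a limit, > 100000 nM (the limit of > 100000 nM in this assay, at which 1 of the 3 values shown sits). Compound 4 `CCC(=O)Nc1ccc(-c2nc3ccccc3[nH]2)cc1` has not yet been measured in this assay. It differs from compound 2 in one place: methyl in place of pyrrolidin-1-yl on a saturated chain carbon bound to a carbonyl carbon. Among the compounds with values here, no pair of measured compounds differs in exactly this way, so no measured step guides the expectation. The account therefore expects compound 4 to sit close to compound 2 in this assay, with an expected step of a 1.1-fold lower number from compound 2 to compound 4 (0.04 log units; within the scatter) that stays within the scatter. The estimate for compound 4 in this assay is 50000 nM, with a range from 15000 nM to 150000 nM.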

Compound 4, half-maximal cytotoxic concentration: >= 100000 nM
Compound 4: only a limit was reported; the forecaster's own chance of this, stated with the estimate: 25%; at least 2.0-fold (0.30 log units) between middle value and limit.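

In this assay the change from pyrrolidin-1-yl to methyl, on a saturated chain carbon bound to a carbonyl carbon, gives the first step read at this place: an at least 1.8-fold higher number from compound 2 to compound 4 (0.25 log units; that floor lies within the scatter). That floor lies within the scatter, so the step alone does not separate the two compounds, but the loss of the ring and its nitrogen brings no sign of a lower number here. On these data alone, compound 4 has only a limit and not a number, so the full size of the step stays unknown: the limit of >= 100000 nM in this assay, at which 1 of the 4 values shown sits.

As far as these compounds go, whether a piperidin-1-yl ring, an open-chain dimethylamino group or a carboxylic acid on this chain carbon would sit with compound 2 or with compound 4 remains open. From the compounds shown here alone, how far the true value of compound 4 lies past its limit also remains open.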